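The source may hold more compounds than are shown below. What is called first, only, known or untested is meant among the compounds shown, and "the series" means these compounds.

In a functional assay on PC-3 cells (Homo sapiens) for cytotoxicity, read by MTT assay, with a stated time of 72 h (a higher number here means a weaker inhibitor, a lower number a stronger inhibitor), compound 1 `O=S(=O)(c1ccccc1)c1nc2ccccc2nc1Nc1ccc(Cl)cc1` gives 15300 nM. Compound 2 `O=S(=O)(c1ccccc1)c1nc2ccccc2nc1Nc1ccc(C(F)(F)F)cc1` differs from it by trifluoromethyl in place of chloro on an aromatic carbon and gives 3550 nM, so that a 4.3-fold lower number from compound 1 to compound 2 (0.63 log units; beyond the scatter). Compound 3 `O=S(=O)(c1ccc(Br)cc1)c1nc2ccccc2nc1Nc1ccc(Cl)cc1` carries a different core, which differs from that of compound 1 by bromo in place of hydrogen on an aromatic carbon; compound 3 gives 7460 nM, and a 2.1-fold lower number from compound 1 to compound 3 (0.31 log units; beyond the scatter). Compound 4 `O=S(=O)(c1ccc(Br)cc1)c1nc2ccccc2nc1Nc1ccc(C(F)(F)F)cc1` has not yet been measured. It stands to compound 3 as compound 2 stands to compound 1: the change is trifluoromethyl in place of chloro on an aromatic carbon, the same change that was already made once, at the same place, so that it is seen twice among these four compounds. For compound 4 a step of roughly the same size as the earlier one is expected in this assay, namely a 3.9-fold lower number from compound 3 to compound 4 (0.59 log units; beyond the scatter). This expectation rests on the step of a 4.3-fold lower number from compound 1 to compound 2 (0.63 log units; beyond the scatter) on the core of compound 1, with the caution that the same change on a different core is not guaranteed to repeat; the starting point is compound 3, which gives 7460 nM. Compound 4 is therefore estimated at 1900 nM, with a plausible range from 900 nM to 4200 nM.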

Compound 4, half-maximal inhibitory concentration: 4150 nM
Compound 4: the middle estimate sits 2.2-fold (0.34 log units) below what was measured; the range from low to high includes it.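

In this assay, trifluoromethyl in place of chloro on the bromo-bearing core gives a 1.8-fold lower number from compound 3 to compound 4 (0.25 log units; within the scatter) and so does not stand clear of the scatter on its own, yet it does not depart measurably from the step on the core of compound 1: the same change on two cores in this assay, a 4.3-fold lower number (0.63 log units; beyond the scatter) from compound 1 to compound 2 and a 1.8-fold lower number (0.25 log units; within the scatter) from compound 3 to compound 4, 2.4-fold (0.38 log units) apart, within the scatter of two such steps. Bromo in place of hydrogen, now read with trifluoromethyl present, gives a 1.2-fold higher number from compound 2 to compound 4 (0.07 log units; within the scatter) and likewise cannot be told apart from the earlier step: the same change on two cores in this assay, a 2.1-fold lower number (0.31 log units; beyond the scatter) from compound 1 to compound 3 and a 1.2-fold higher number (0.07 log units; within the scatter) from compound 2 to compound 4, 2.4-fold (0.38 log units) apart, within the scatter of two such steps. Both changes are thus compatible with carrying over from one core to the other, but this does not show that the steps are equal, since a single pair per change cannot separate a true shrinking of the step from scatter. 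

What the compounds shown leave open is whether an amine, a nitrile or a methoxy group in place of the chloro would follow the same course. As far as these compounds go, it is also open whether a carboxylic acid or a longer chain in place of the bromo would leave the trifluoromethyl step as it stands here.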